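Exchanging the aryl group on compound 3

The source may hold more compounds than are shown below. What is called first, only, known or untested is meant among the compounds shown, and "the series" means these compounds.

In an ADME assay on the whole organism (Mus musculus, strain CD-1) for pharmacokinetics, at a dose of 10 mg/kg by the oral route (on this read-out lower numbers stand for lower exposure and higher numbers for higher exposure at the dose given), compound 3 `COc1cc([C@](O)(CCN(C)C)[C@@H](c2cc3cc(Br)ccc3nc2OC)c2cccc(OC)c2F)cc(OC(F)F)n1` gives 14400 ng.h/mL. Compound 1 `CCOc1cc([C@](O)(CCN(C)C)[C@@H](c2cc3cc(Br)ccc3nc2OC)c2ccnc(OC)c2OC)cc(OC)n1` gives 12700 ng.h/mL, and this value lies within the scatter of that of compound 3. Compound 2 `COc1cc([C@](O)(CCN(C)C)[C@@H](c2cc3cc(Br)ccc3nc2OC)c2ccnc(OC)c2OC)cc(OC(C)C)n1` gives 5600 ng.h/mL, and the gap between this value and that of compound 3 lies outside the scatter. Compound 4 `COc1cc([C@](O)(CCN(C)C)[C@@H](c2cc3cc(Br)ccc3nc2OC)c2ccnc(OC)c2OC)cc(OC(F)F)n1` carries 2,3-dimethoxypyridin-4-yl in place of 2-fluoro-3-methoxyphenyl on a saturated chain carbon bound to an aromatic carbon and a saturated chain carbon. Within the data shown here, no measured step covers this exchange. Among the measured compounds shown here, the only step available, a 2.3-fold lower number from compound 1 to compound 2 (0.36 log units; beyond the scatter), is modest and involves a different change, though both of its compounds carry the entering group. The step expected in this assay is a 1.4-fold lower number from compound 3 to compound 4 (0.16 log units; within the scatter), within the scatter. For compound 4 the estimated value is 10000 ng.h/mL, with an expected range from 4500 ng.h/mL to 20000 ng.h/mL.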

Compound 4, area under the concentration-time curve: 9800 ng.h/mL
Estimate against measurement, compound 4: 1.0-fold (0.01 log units) above; measured number inside the range.
By their numbers in this assay, from the lowest: compounds 2, 4, 1 and 3 (each within the scatter of the next, the first and the last beyond it).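

In this assay the aryl exchange on a saturated chain carbon bound to an aromatic carbon and a saturated chain carbon gives a 1.5-fold lower number from compound 3 to compound 4 (0.17 log units; within the scatter) and so leaves the read-out within the scatter with either 2-fluoro-3-methoxyphenyl or 2,3-dimethoxypyridin-4-yl. On an oxygen on an aromatic ring, difluoromethyl gives a 1.8-fold higher number from compound 2 to compound 4 (0.24 log units; within the scatter) in place of isopropyl and a 1.3-fold lower number from compound 1 to compound 4 (0.11 log units; within the scatter) in place of ethyl. Open remains how an aryl group bearing an amine would read at this place, and whether the exchange keeps its size with isopropyl on the oxygen. No available evidence bears on a cause for these steps.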